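Adding a Second Methyl to Compound 2

The compounds below may be only part of what the source reports. "The series", "measured", "known", "first", "only" and "open" are said of these compounds alone.

Among the measured compounds shown here, in a functional assay on aorta (Rattus norvegicus, strain Wistar), in the presence of a further agent that is not named here (a lower number here means a stronger inhibitor, a higher number a weaker inhibitor), compound 2 `CC1CN(C2=CCCC2=O)c2cc(C(F)(F)F)ccc2S1` gives 708 nM, the higher of the two numbers measured so far. Compound 1 `CC(=O)c1ccc2c(c1)N(C1=CCCC1=O)CC(C)(C)S2` gives 56.2 nM, a lower number beyond the scatter. Compound 3 `CC1(C)CN(C2=CCCC2=O)c2cc(C(F)(F)F)ccc2S1` puts methyl in place of hydrogen on a saturated ring carbon, next to the ring sulfur (methyl in place of hydrogen on a saturated ring carbon). For the measured compounds named here, no measured pair shows this change alone, so the expectation rests only on the lower value of compound 1 at 56.2 nM. A moderate step to a lower number, beyond the scatter, is expected, estimated as a 4.2-fold lower number from compound 2 to compound 3 (0.62 log units; beyond the scatter). The estimate for compound 3 is 170 nM, with an expected range from 45 nM to 600 nM.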

Compound 3, half-maximal inhibitory concentration: 8.32 nM
For compound 3 the middle estimate is 20-fold (1.31 log units) above the measured one; measured number below the stated range.
By their numbers in this assay, from the lowest: compound 3; then compound 1; then compound 2.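

In this assay, among the compounds shown here, the second methyl on the saturated ring carbon next to the ring sulfur gives an 85-fold lower number from compound 2 to compound 3 (1.93 log units; beyond the scatter) and so counts as a large step, the first reading of this change alone. Placing trifluoromethyl in place of acetyl on an aromatic carbon, with both methyls present, gives a 6.8-fold lower number from compound 1 to compound 3 (0.83 log units; beyond the scatter) as a modest step. Nothing available here accounts for either step. Still open, going by these compounds, is whether an ethyl group or a longer chain on this ring carbon would keep the low number. Also open, on these data alone, is whether a nitrile on the aromatic carbon would match trifluoromethyl.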